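Replacing a Hydroxy Group with a Thiazolidinedione

A few compounds are considered here, and "the series" means these few. Any claim that something is new, unique, unknown or untested is made for them only; others in the source may bear on it.

Compound 1, `O=C1O[C@@H](CO)CN1c1ccc(-n2cc(-c3ccccn3)cn2)c(F)c1`: in an ADME assay on HEK293-A cells (Homo sapiens) for cytotoxicity, read by MTT assay, with a stated time of 48 h (a higher number here means a weaker inhibitor, a lower number a stronger inhibitor), compound 1 gives a limit, > 400 ug/mL.
Compound 2, `COC(=O)CC1CCN(C[C@H]2CN(c3ccc(-n4cc(-c5ccccn5)cn4)c(F)c3)C(=O)O2)CC1`: in this assay compound 2 gives 224 ug/mL.
Compound 3, `O=C1O[C@@H](CN2CCC(O)CC2)CN1c1ccc(-n2cc(-c3ccccn3)cn2)c(F)c1`: in this assay compound 3 gives a limit, > 400 ug/mL.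

Compound 1 stands at the edge of what this assay can report; (the limit of > 400 ug/mL in this assay, at which 2 of the 3 values shown sit). Compound 4, `O=C1CSC(=O)N1C[C@H]1CN(c2ccc(-n3cc(-c4ccccn4)cn3)c(F)c2)C(=O)O1`, differs from compound 1 in one place: 2,4-dioxo-1,3-thiazolidin-3-yl in place of hydroxy on a saturated chain carbon bound to a saturated ring carbon. The measured steps at that place are an at least 1.7-fold lower number from compound 1 to compound 2 (0.25 log units; that floor lies within the scatter) and a step that the two limits leave unreadable from compound 1 to compound 3, with an at least 1.7-fold higher number from compound 2 to compound 3 (0.25 log units; that floor lies within the scatter) between the two products. Larger groups on that chain carbon have moved the number little, so for compound 4 no step beyond the scatter is expected in this assay. The expected step is an at least 1.1-fold lower number from compound 1 to compound 4 (0.07 log units; that floor lies within the scatter). Compound 4 is estimated at 340 ug/mL, within 150 ug/mL to 500 ug/mL.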

Compound 4, half-maximal inhibitory concentration: 283 ug/mL
Compound 4: the middle estimate sits 1.2-fold (0.08 log units) above what was measured; the range from low to high includes it.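

On a saturated chain carbon bound to a saturated ring carbon, the 2,4-dioxo-1,3-thiazolidin-3-yl group, which holds no piperidine, cannot be told apart in this assay from the 4-((methoxycarbonyl)methyl)piperidin-1-yl group, with a 1.3-fold higher number from compound 2 to compound 4 (0.10 log units; within the scatter). Against the two hydroxy-bearing groups it gives an at least 1.4-fold lower number from compound 1 to compound 4 (0.15 log units; that floor lies within the scatter) and an at least 1.4-fold lower number from compound 3 to compound 4 (0.15 log units; that floor lies within the scatter). Neither of these two steps has a true size, because compound 1 and compound 3 each sit at a limit: the limit of > 400 ug/mL in this assay, at which 2 of the 4 values shown sit.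

The compounds shown leave open whether a carboxylic acid or a primary amine at this place would also stay within this range.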